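This account rests on a few compounds, and the source may have more. Where it says the series, first, only, none or still open, it means among the compounds named here.

Compound 2 has the structure `CC1(C)CC(NCCCCO)=Nc2ccc(Cl)cc21`. Going by the values given here, in a functional assay on MDA-MB-231 cells (Homo sapiens) for cytotoxicity, read by MTT assay, with a stated time of 72 h, tested at 5 uM, in the absence of a further agent (a lower number here means a stronger effect, a higher number a weaker effect of the compound at the concentration tested), compound 2 gives 84.9%, which is the highest of the two numbers measured so far, meaning that at the tested concentration it leaves most of the cells alive and so shows only a weak effect. Its nearest neighbour is compound 1, with the structure `CCCNC1=Nc2ccc(Cl)cc2C(C)(C)C1`; in this assay compound 1 gives 82.4%. The step of a number 2.5 percentage points higher from compound 1 to compound 2 (within the scatter) lies within the scatter, so the two compounds cannot be told apart on these numbers.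

Compound 3, the next compound, has the structure `CCN(CC)CCCNC1=Nc2ccc(Cl)cc2C(C)(C)C1`. It differs from compound 2 in one place: diethylamino in place of hydroxymethyl on a saturated chain carbon, three bonds along the chain from an amine nitrogen. Among the compounds with values here, the only measured step that bears on this place is the one from compound 1 to compound 2, a number 2.5 percentage points higher from compound 1 to compound 2 (within the scatter), where putting a hydroxymethyl group onto that chain carbon changed nothing beyond the scatter. Within the data shown here, with only that one small step to go on, no step beyond the scatter is expected for compound 3 in this assay, that is a number 4.9 percentage points lower from compound 2 to compound 3 (within the scatter) as the expected change. The estimate for compound 3 is therefore 80%, with a likely range from 62% to 95%.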

Compound 3, a percentage reported as activity, at one concentration (the size of the read-out at that concentration, not a potency): 36.1%
Compound 3: middle estimate off by 43.9 percentage points, on the high side; the measured number lies below the stated range.
By their numbers in this assay, from the lowest: compound 3; then compounds 1 and 2 (each within the scatter of the next).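

The earlier pair suggested that this saturated chain carbon, three bonds along the chain from an amine nitrogen, was a quiet place, but in this assay the result with diethylamino there is a number 48.8 percentage points lower from compound 2 to compound 3 (beyond the scatter) when it replaces hydroxymethyl and a number 46.3 percentage points lower from compound 1 to compound 3 (beyond the scatter) when it replaces hydrogen. The outcome therefore depends strongly on which group sits at this place: hydrogen and hydroxymethyl cannot be told apart, while diethylamino gives a much lower number, which here means a stronger effect on the cells at the tested concentration. Nothing available explains why diethylamino behaves so differently from the other two groups.

The compounds shown leave open whether this large step needs the two ethyl groups on the nitrogen or whether a simpler amine, such as dimethylamino or an unsubstituted amino group, or a ring amine such as piperidine, would do the same. They also leave open whether a carbon-only group of similar size, such as a plain pentyl chain, would give a comparable number, and how a longer or shorter chain carrying diethylamino would fare.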